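This account rests on a few compounds, and the source may have more. Where it says the series, first, only, none or still open, it means among the compounds named here.

Compound 1, `COc1ccc2[nH]cc(/C=C(\C#N)C(=O)c3c[nH]c4ccccc34)c2c1`, was tested in a functional assay on A549 cells (Homo sapiens) for cytotoxicity, read by WST assay, with a stated time of 48 h (a higher number here means a weaker inhibitor, a lower number a stronger inhibitor), where compound 1 gives 13700 nM. Two related compounds share a different core. Compound 3, `N#C/C(=C\c1c[nH]c2cc(F)ccc12)C(=O)c1c[nH]c2ccccc12`, gives 22700 nM in this assay, and its value and that of compound 1 lie within the scatter of each other. Compound 2, `N#C/C(=C\c1c[nH]c2cc(F)ccc12)C(=O)c1c[nH]c2cc(F)ccc12`, gives 36100 nM in this assay, a number that stands beyond the scatter from the value of compound 1. How the core of compound 1 differs from the core of compound 3 is not broken down here.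

Between compound 3 and compound 2 a single change was made: fluoro in place of hydrogen on an aromatic carbon In this assay it produced a 1.6-fold higher number from compound 3 to compound 2 (0.20 log units; within the scatter), so the entering fluoro left the read-out essentially where it was.

Compound 4, `COc1ccc2[nH]cc(/C=C(\C#N)C(=O)c3c[nH]c4cc(F)ccc34)c2c1`, has not yet been measured. Among the measured compounds shown here, it differs from compound 1 by the same change, at the same place on the six-membered aromatic ring of carbon only: fluoro in place of hydrogen on an aromatic carbon Since the one example of this change, from compound 3 to compound 2, gave only a 1.6-fold higher number from compound 3 to compound 2 (0.20 log units; within the scatter), a step of similar size is expected for compound 4, namely a 1.5-fold higher number from compound 1 to compound 4 (0.19 log units; within the scatter) in this assay. On that basis compound 4 is estimated to give 21000 nM in this assay, with the expected range running from 9000 nM to 45000 nM.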

Compound 4, half-maximal inhibitory concentration: 26300 nM
Estimate against measurement, compound 4: 1.3-fold (0.10 log units) below; the range from low to high includes it.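

On the core of compound 1, fluoro in place of hydrogen on an aromatic carbon, set on a six-membered aromatic ring of carbon only, gave in this assay a 1.9-fold higher number from compound 1 to compound 4 (0.28 log units; within the scatter), so the read-out again stayed where it was. Set beside the earlier example, the change carries from one core to the other without a difference that can be told apart: the same change on two cores in this assay, a 1.6-fold higher number (0.20 log units; within the scatter) from compound 3 to compound 2 and a 1.9-fold higher number (0.28 log units; within the scatter) from compound 1 to compound 4, 1.2-fold (0.08 log units) apart, within the scatter of two such steps. This shows agreement in a narrow sense, since both steps are small and neither can be separated from repeated measurement, so the two cores agree in showing no clear response to this fluoro rather than in sharing a defined effect, and two cores and a single place are too few to establish a rule for the wider series.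

The compounds shown leave open whether a different group at the same place, such as chloro, an amine or a carboxylic acid, would move the number beyond the scatter in this assay. They also leave open whether fluoro at another place on the ring, or on a third core, would behave as it did in these two pairs.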